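The source may report more compounds than this note shows. Statements on the series, on what has been measured and on what is new or still open speak of the compounds shown alone.

Measured compounds:

Compound 1 `COc1ccc(/C=N/N(C(C)=O)c2nc(C)c[se]2)cc1`: in a functional assay on HepG2 cells (Homo sapiens) for cytotoxicity, read by XTT assay, with a stated time of 72 h (on this read-out lower numbers stand for stronger inhibition and higher numbers for weaker inhibition), compound 1 gives > 74300 nM, which is a limit of the assay and not a number.
Compound 2 `COc1ccc(/C=N/N(C(C)=O)c2nc(-c3ccccc3)c[se]2)cc1`: in this assay compound 2 gives > 62700 nM, again a limit of the assay.
Compound 3 `Cc1c[se]c(NNC(=O)c2ccccc2)n1`: in this assay compound 3 gives > 89200 nM, also a limit of the assay.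

The change from compound 1 to compound 2 is phenyl in place of methyl on an aromatic carbon. The step that the two limits leave unreadable from compound 1 to compound 2 cannot be sized. Compound 1 sits at the limit of > 74300 nM in this assay, at which 1 of the 3 values shown sits. Compound 2 sits at the limit of > 62700 nM in this assay, at which 1 of the 3 values shown sits. Both ends are limits, so the step has no readable size in either direction.

Compound 3 stands at the limit of > 89200 nM in this assay, at which 1 of the 3 values shown sits. How the core of compound 3 differs from the core of compound 1 is not broken down here.

Compound 4 `O=C(NNc1nc(-c2ccccc2)c[se]1)c1ccccc1` has not yet been measured in this assay. It differs from compound 3 by phenyl in place of methyl on an aromatic carbon. The place of this change is described in the same words as for the change from compound 1 to compound 2, so it is the same change made on a second core.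

For compound 4 the step that the limit leaves unreadable from compound 3 to compound 4 is expected to be close to flat, resting on the fact that the same change from compound 1 to compound 2 left both compounds at limits and on compound 3 standing at the limit of > 89200 nM in this assay, at which 1 of the 3 values shown sits. Compound 4 is therefore estimated at 90000 nM, within 25000 nM to 250000 nM, most likely reported as a limit again.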

Compound 4, half-maximal inhibitory concentration: > 73000 nM
Compound 4 was reported as a limit; the forecaster's own chance of this, stated with the estimate: 80%; the middle value is on the limit's open side.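

In this assay compound 4 gives > 73000 nM, which is a limit of the assay and not a number. Compound 3 gives > 89200 nM, also a limit, so no step can be read between compound 3 and compound 4. The compounds shown leave open whether phenyl in place of methyl on an aromatic carbon changes the value in this assay at all, on either core.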